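The source may report more compounds than this note shows. Statements on the series, on what has been measured and on what is new or still open speak of the compounds shown alone.

Two compounds measured in an assay on CHO cells for displacement of a labelled ligand from prostaglandin D2 receptor 2 (Homo sapiens), read by scintillation counting (a lower number here means a stronger inhibitor, a higher number a weaker inhibitor), set the frame for this step. Compound 1 `CC1(O)c2ccc(C#Cc3cc(Cl)ccc3OCC(=O)O)cc2S(=O)(=O)C1(C)C` gives 28 nM in this assay. Compound 2 `COCCNS(=O)(=O)c1ccc(C)c(C#Cc2cc(Cl)ccc2OCC(=O)O)c1` gives 3.6 nM in this assay, the lowest of the two numbers shown, and the gap to compound 1 lies beyond the scatter. Going by the values given here, no pair of these two differs in only one place, so the comparison between them says nothing about any single change.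

Compound 3 `Cc1ccc(S(=O)(=O)NC(C)(C)C)cc1C#Cc1cc(Cl)ccc1OCC(=O)O` has not yet been measured in this assay. Its difference from compound 2 is tert-butyl in place of 2-methoxyethyl on a sulfonamide nitrogen. Both groups carry four heavy atoms and neither carries a hydrogen-bond donor; the one that leaves carries one hydrogen-bond acceptor and the one that enters carries none.

Among the compounds with values here, nothing among the measured compounds tells how a change at the sulfonamide nitrogen moves the number, so the expected step for this assay from compound 2 to compound 3 is estimated as a 1.4-fold higher number from compound 2 to compound 3 (0.14 log units; within the scatter), a small shift that is within the scatter. Compound 3 is therefore expected to give about 5 nM in this assay, with a range from 1.5 nM to 16 nM.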

Compound 3, inhibition constant: 5 nM
Compound 3: the middle estimate sits on the measured number at the digits printed; low and high end bracket the measured number.
By their numbers in this assay, from the lowest: compounds 2 and 3 (each within the scatter of the next); then compound 1.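

Going by these compounds alone, the pair of compound 2 and compound 3 gives the first comparison in this set that isolates one change: in this assay, tert-butyl in place of 2-methoxyethyl on the sulfonamide nitrogen gives a 1.4-fold higher number from compound 2 to compound 3 (0.14 log units; within the scatter) and so leaves the number within the scatter. For this pair, the hydrogen-bond acceptor counted in 2-methoxyethyl can therefore be absent from the group on that nitrogen without a step beyond the scatter, and two different groups of equal heavy-atom count are read alike at this place. No measurement shown here explains this result.

The compounds shown leave open whether a hydrogen, a methyl group, a cyclopropyl ring, a longer chain, or a chain ending in an amine or a carboxylic acid on the same nitrogen would also stay within the scatter of these two compounds. The steps from compound 1 to compound 2 and to compound 3 cannot be read, as compound 1 differs from each in more than one place, so its gap cannot be assigned to any single part of the structure.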